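Aryl change at the ring nitrogen: compound 2 to compound 4

A few compounds are considered here, and "the series" means these few. Any claim that something is new, unique, unknown or untested is made for them only; others in the source may bear on it.

Among the compounds with values here, compound 2 `CCCc1nc(-c2ccccc2)c(CNCCCN2CCN(c3cccc(OC)c3)CC2)o1` carries the lowest of the three numbers measured so far in an assay on HEK293 cells for inhibition of Voltage-dependent T-type calcium channel subunit alpha-1G (Homo sapiens), read by fluorescence, tested at 10 uM (a lower number here means less inhibition, a higher number more inhibition at the concentration tested (going by the name of the read-out)), where compound 2 gives 36.4%. Compound 3 `CCCc1nc(-c2ccccc2)c(CNCCN2CCN(c3cccc(OC)c3)CC2)o1` gives 40.2%, which lies within the scatter of compound 2, so no order between these two is claimed. Compound 1 `CCCc1nc(-c2ccccc2)c(CNCCN2CCN(c3ccccc3F)CC2)o1` gives 46.5%, and its gap to compound 2 lies beyond the scatter. Within the data shown here, the only single-point step measured in this set, a number 6.3 percentage points lower from compound 1 to compound 3 (within the scatter), exchanges the aryl on the ring nitrogen and stays within the scatter.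

Compound 4 `CCCc1nc(-c2ccccc2)c(CNCCCN2CCN(c3cccc(C)c3C)CC2)o1` differs from compound 2 by 2,3-dimethylphenyl in place of 3-methoxyphenyl on an amine nitrogen in a ring. Among the measured compounds shown here, no measured step exchanges a methoxy-bearing aryl for a dimethyl-bearing aryl at this position, so the bearing evidence is the one aryl exchange available, which moved the read-out within the scatter. A step within the scatter is therefore expected here as well, with no clear direction. Compound 4 is expected to give 38% in this assay, with a range from 25% to 52%. This estimate means a step of a number 1.6 percentage points higher from compound 2 to compound 4 (within the scatter), expected to stay within the scatter.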

Compound 4, a percentage reported as inhibition, at one concentration (the size of the read-out at that concentration, not a potency): 55.2%
Compound 4: middle estimate off by 17.2 percentage points, on the low side; the measured number lies above the stated range.
By their numbers in this assay, from the lowest: compounds 2, 3, 1 and 4 (each within the scatter of the next, the first and the last beyond it).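

In this assay, the aryl on the amine nitrogen in the ring can move the read-out beyond the scatter: 2,3-dimethylphenyl in place of 3-methoxyphenyl gives a number 18.8 percentage points higher from compound 2 to compound 4 (beyond the scatter), whereas the earlier aryl exchange at this position gave a number 6.3 percentage points lower from compound 1 to compound 3 (within the scatter). So the flat picture suggested by that earlier exchange does not hold for every aryl pair at this position, and the two compounds in the new step share the rest of their structure. The two aryl groups match in heavy-atom count, and the entering group is carbon only with no hydrogen-bond acceptor, but no evidence in hand connects either feature to the size of the step.

Still open, from the compounds shown here alone, is whether both methyl groups are needed, which 2-methylphenyl and 3-methylphenyl at the same nitrogen would test, and whether 2,3-dichlorophenyl behaves like 2,3-dimethylphenyl. Also open, going by these compounds, is whether 2,3-dimethylphenyl gives a similar step on the chain of compound 3, and how these single-concentration percentages relate to potency.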